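A few compounds are considered here, and "the series" means these few. Any claim that something is new, unique, unknown or untested is made for them only; others in the source may bear on it.

Of the compounds shown here, two have been measured in an assay on cells for antagonist activity at P2X purinoceptor 4 (Homo sapiens), read by fluorescence and calcium flux, with a stated time of 30 min; a higher number here means a weaker inhibitor, a lower number a stronger inhibitor. Going by the values given here, compound 1 `O=C(Nc1cccc(C(F)(F)F)c1)c1cc(Cl)ccc1O` gives 537 nM in this assay, the lowest of the two numbers so far. Compound 2 `O=C(Nc1ccc(C(F)(F)F)cc1)c1cc(Cl)ccc1O` gives 1500 nM in this assay, a higher number than that of compound 1 by a gap beyond the usual scatter. Compound 3 `O=C(Nc1cc([N+](=O)[O-])cc(C(F)(F)F)c1)c1cc(Cl)ccc1O` has not yet been measured. It differs from compound 1 in one place: nitro in place of hydrogen on an aromatic carbon. Among the compounds with values here, no pair of measured compounds shows what such a change does here, so the size of the step is uncertain. A modest move toward a lower number is expected, meaning compound 3 is expected to be a somewhat stronger inhibitor, with the expected step of a 2.4-fold lower number from compound 1 to compound 3 (0.39 log units; beyond the scatter) reaching only a little beyond the scatter. For compound 3 the estimated value in this assay is 220 nM, with an expected range from 60 nM to 800 nM.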

Compound 3, half-maximal inhibitory concentration: 42.6 nM
Estimate against measurement, compound 3: 5.2-fold (0.71 log units) above; the measured number lies below the stated range.
By their numbers in this assay, from the lowest: compound 3; then compound 1; then compound 2.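

Placing a nitro group on this aromatic carbon, meta to a trifluoromethyl group, gives a 13-fold lower number from compound 1 to compound 3 (1.10 log units; beyond the scatter) in this assay, a large move toward stronger inhibition. Going by these compounds alone, this is the first sign that the carbon is open to substitution and that a single added group there can change the reading by far more than the usual scatter. Nothing available bears on why the step is this large.

A single group at one carbon cannot show whether the gain is specific to nitro or would also come with a nitrile, an amine or a carboxylic acid in the same place. On these data alone, it also remains open whether nitro would give a similar step on another carbon of this ring, or whether the trifluoromethyl group is still needed once nitro is present.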